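The source may hold more compounds than are shown below. What is called first, only, known or untested is meant among the compounds shown, and "the series" means these compounds.

Among the compounds with values here, compound 1, `CN(C)C(=O)c1cc2cnc(Nc3ccc(NC(=O)C4(C(=O)Nc5ccc(F)cc5)CC4)cc3)nc2n1C1CCCC1`, gives 102% in a functional assay on A549 cells (Homo sapiens) for inhibition, read by CCK-8 assay, with a stated time of 72 h, tested at 10 uM (a higher number here means more inhibition of growth at the concentration tested, a lower number less inhibition of growth), the highest of the three numbers measured so far. Compound 2, `CN(C)C(=O)c1cc2cnc(Nc3ccc(NC(=O)C4(C(=O)Nc5ccccc5F)CC4)cc3)nc2n1C1CCCC1`, gives 88.6%, and compound 3, `CN(C)C(=O)c1cc2cnc(Nc3ccc(NC(=O)C4(C(=O)Nc5ccc(Br)cc5)CC4)cc3)nc2n1C1CCCC1`, gives 90.3%. Compound 4, `CN(C)C(=O)c1cc2cnc(Nc3ccc(NC(=O)C4(C(=O)Nc5ccc(Cl)c(C(F)(F)F)c5)CC4)cc3)nc2n1C1CCCC1`, is not yet measured; it differs from compound 1 in one place: 4-chloro-3-(trifluoromethyl)phenyl in place of 4-fluorophenyl on an amide-type nitrogen. Within the data shown here, two measured steps bear on this. Putting bromo in place of fluoro on that ring gave a number 11.7 percentage points lower from compound 1 to compound 3 (beyond the scatter), and putting 2-fluorophenyl in place of 4-fluorophenyl gave a number 13.4 percentage points lower from compound 1 to compound 2 (beyond the scatter). Both changes to this ring lowered growth inhibition by a modest amount, so a similar modest drop is expected here, a number 14 percentage points lower from compound 1 to compound 4 (beyond the scatter). Compound 4 is therefore estimated to give 88%, within a range from 72% to 100%.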

Compound 4, percent growth inhibition at one concentration: 88.1%
Beside the measured number, compound 4's estimate is 0.1 percentage points below it; low and high end bracket the measured number.
By their numbers in this assay, from the lowest: compounds 4, 2 and 3 (each within the scatter of the next); then compound 1.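

In this assay, 4-chloro-3-(trifluoromethyl)phenyl, with 11 heavy atoms against 7 in 4-fluorophenyl, gives a number 13.9 percentage points lower from compound 1 to compound 4 (beyond the scatter). Its result still matches those of the two smaller replacements, with a number 2.2 percentage points lower from compound 3 to compound 4 (within the scatter) and a number 0.5 percentage points lower from compound 2 to compound 4 (within the scatter), so among these compounds the extra heavy atoms bring no further drop, and only compound 1 stands apart. Nothing measured here explains why 4-fluorophenyl gives the highest number. Still open, going by these compounds, is whether this amide-type nitrogen needs an aromatic ring at all, or whether a cyclohexyl group or a pyridine ring would serve as well.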